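A Methyl Added to Compound 3 in a Growth Assay

A few compounds are considered here, and "the series" means these few. Any claim that something is new, unique, unknown or untested is made for them only; others in the source may bear on it.

Compound 3 `Cc1nc(C)c(-c2nn(-c3ccc(F)cc3)cc2/C=C/C(=O)c2cc(Cl)c(C)cc2O)s1` is one of three compounds tested in an ADME assay on A549 cells (Homo sapiens) for inhibition, read by MTT assay (on this read-out lower numbers stand for stronger inhibition of growth and higher numbers for weaker inhibition of growth), and each of them returns only a limit. In this assay compound 3 gives > 250 ug/mL, which is a limit. Compound 1 `Cc1nc(C)c(-c2nn(-c3ccc(F)cc3)cc2/C=C/C(=O)c2cc(Br)ccc2O)s1` gives a limit of > 250 ug/mL in this assay. Compound 2 `Cc1nc(C)c(-c2nn(-c3ccc(F)cc3)cc2/C=C/C(=O)c2cc(Cl)cc(Cl)c2O)s1` gives a limit of > 250 ug/mL in this assay. The steps a step that the two limits leave unreadable from compound 1 to compound 2, a step that the two limits leave unreadable from compound 1 to compound 3 and a step that the two limits leave unreadable from compound 2 to compound 3 therefore cannot be read, since (the limit of > 250 ug/mL in this assay, at which 3 of the 3 values shown sit). Compound 4 `Cc1nc(C)c(-c2nn(-c3ccc(F)cc3)cc2/C=C/C(=O)c2c(O)cc(C)c(Cl)c2C)s1` differs from compound 3 by methyl in place of hydrogen on an aromatic carbon. For the measured compounds named here, no measured step of readable size bears on this change, so the data give no anchor for its direction or size. Compound 4 is expected to give 300 ug/mL, between 120 ug/mL and 800 ug/mL, most probably again as a limit, the expected step from compound 3 being a step that the limit leaves unreadable from compound 3 to compound 4.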

Compound 4, concentration for 50% growth inhibition: 33.5 ug/mL
Estimate against measurement, compound 4: 9.0-fold (0.95 log units) above, and the stated range ends above it.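

In this assay, for the compounds shown here, the methyl, on an aromatic carbon ortho to a chloro group, gives the first readable step in this set: an at least 7.4-fold lower number from compound 3 to compound 4 (0.87 log units; beyond the scatter). The 3-chloro-6-hydroxy-2,4-dimethylphenyl group also reads against the other two groups on the carbonyl carbon, with an at least 7.4-fold lower number from compound 2 to compound 4 (0.87 log units; beyond the scatter) and an at least 7.4-fold lower number from compound 1 to compound 4 (0.87 log units; beyond the scatter). Compound 1, compound 2 and compound 3 all remain at a limit: the limit of > 250 ug/mL in this assay, at which 3 of the 4 values shown sit.

From the compounds shown here alone, each step therefore gives only a minimum size, and the full size of the methyl's step stays open. Going by these compounds, whether an ethyl or a methoxy group on this carbon would give a similar number also stays open.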